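Chloro on the anilino ring of compound 2

The source may hold more compounds than are shown below. What is called first, only, known or untested is meant among the compounds shown, and "the series" means these compounds.

Measured so far in a functional assay on HepG2 cells (Homo sapiens) for antiproliferative activity, read by CCK-8 assay, with a stated time of 72 h, tested at 8 uM; on this read-out lower numbers stand for a weaker effect and higher numbers for a stronger effect at the one concentration tested:
compound 1 `CC(C)n1cnc2c(Nc3ccccc3)nc(NCOCc3ccc(C(=O)Nc4ccccc4N)cc3)nc21` gives 50.2%
compound 2 `CC(C)n1cnc2c(Nc3ccccc3)nc(NCOCc3ccc(/C=C/C(=O)Nc4ccccc4N)cc3)nc21` gives 40.8%

Compound 2 stands next to compound 1 on the numbers shown: the only recorded step, a number 9.4 percentage points lower from compound 1 to compound 2 (within the scatter), is within the scatter, so the two compounds are not separated by this assay.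

Compound 3 `CC(C)n1cnc2c(Nc3cccc(Cl)c3)nc(NCOCc3ccc(/C=C/C(=O)Nc4ccccc4N)cc3)nc21` differs from compound 2 in one place: chloro in place of hydrogen on an aromatic carbon. The change sits on the six-membered aromatic ring of carbon only that carries the anilino nitrogen, so that the anilino becomes (3-chlorophenyl)amino.

For the measured compounds named here, no measured step concerns a chloro in place of hydrogen on that ring; the one measured step concerns the amide side of the molecule and was within the scatter. With nothing in the measured pair bearing on this change, compound 3 is expected to stay within the scatter of compound 2, a step of a number 2.2 percentage points higher from compound 2 to compound 3 (within the scatter) in this assay. Compound 3 is therefore estimated at 43%, between 30% and 58%.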

Compound 3, a percentage reported as inhibition, at one concentration (the size of the read-out at that concentration, not a potency): 49.9%
Compound 3: middle estimate off by 6.9 percentage points, on the low side; measured number inside the range.
By their numbers in this assay, from the lowest: compounds 2, 3 and 1 (each within the scatter of the next).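

In this assay the step for chloro in place of hydrogen on the anilino ring is a number 9.1 percentage points higher from compound 2 to compound 3 (within the scatter) and is the only one shown on this ring, so phenyl and 3-chlorophenyl are not separated at this place. With the 2-((2-aminophenyl)carbamoyl)ethenyl group on the other side of the molecule, this position therefore accepts a chlorine without a step beyond the scatter at the one concentration tested. No measurement shown here offers an explanation for this result.

As far as these compounds go, whether a methoxy, an amine or a carboxylic acid at this place would give a step beyond the scatter remains open. Also open, from the compounds shown here alone, is how chloro at this place reads out alongside the (2-aminophenyl)carbamoyl group of compound 1.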